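The source may hold more compounds than are shown below. What is called first, only, known or untested is meant among the compounds shown, and "the series" means these compounds.

In a functional assay on NCI-H460 cells (Homo sapiens) for cytotoxicity (a lower number here means a stronger inhibitor, a higher number a weaker inhibitor), two compounds have been measured so far. Compound 1 `COc1ccc2nc(NC(=O)CCCCC(=O)NO)sc2c1` gives 21.4 ug/mL, the higher of the two numbers and so the weaker result, while compound 2 `O=C(CCCCCCC(=O)Nc1nc2ccccc2s1)NO` gives 5.71 ug/mL, a gap beyond the usual scatter. These two differ in more than one place, so no single change can be read from them. Compound 3 `CCOc1ccc2nc(NC(=O)CCCCC(=O)NO)sc2c1` has not yet been measured. It departs from compound 1 in one place: methyl in place of hydrogen on a saturated chain carbon bound to an oxygen on an aromatic ring, or methoxy to ethoxy. For the measured compounds named here, no measured single-place step is available as a guide, so the expected step is a 1.2-fold lower number from compound 1 to compound 3 (0.08 log units; within the scatter), with no change beyond the scatter anticipated in this assay. For compound 3 the estimated value is 18 ug/mL, with an expected range of 8 ug/mL to 40 ug/mL.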

Compound 3, half-maximal inhibitory concentration: 7.96 ug/mL
Compound 3: middle estimate off by 2.3-fold (0.35 log units), on the high side; measured number below the stated range.
By their numbers in this assay, from the lowest: compounds 2 and 3 (each within the scatter of the next); then compound 1.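

For the compounds shown here, the methoxy to ethoxy change gives a 2.7-fold lower number from compound 1 to compound 3 (0.43 log units; beyond the scatter) in this assay and is the first single-place step available for this series. It is modest, but it shows that the saturated chain carbon bound to an oxygen on an aromatic ring is a place where one added methyl moves the number beyond the scatter, which compound 1 and compound 2 could not show because they differ in more than one place. Nothing measured on these compounds accounts for the size or direction of this step.

As far as these compounds go, it remains open whether a longer group at this oxygen, such as propoxy or butoxy, would extend the step or reverse it, and what a free hydroxyl there would give. From the compounds shown here alone, it is also open whether an ethoxy group would give a step of similar size on the longer chain of compound 2.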